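Sulfonamide nitrogen substituent: pyrimidinyl to tolyl

This account rests on a few compounds, and the source may have more. Where it says the series, first, only, none or still open, it means among the compounds named here.

Compound 2 `O=C(Nc1ccc(S(=O)(=O)Nc2ncccn2)cc1)c1ccc(Cl)cc1Cl` stands only at a limit in a functional assay on HEK293 cells for agonist activity at probable G-protein coupled receptor 27 (Homo sapiens), read by a luciferase reporter and beta-arrestin recruitment, with a stated time of 10 min; a lower number here means that less compound is needed, a higher number that more compound is needed for the effect: in this assay compound 2 gives > 100000 nM, which is a limit of the assay and not a number. Compound 1 `O=C(NS(=O)(=O)c1ccc(NC(=O)c2ccc(Cl)cc2Cl)cc1)c1ccccc1` likewise gives > 100000 nM, again a limit. The step that the two limits leave unreadable from compound 1 to compound 2 is accordingly unreadable, and the limit of > 100000 nM in this assay, at which 2 of the 2 values shown sit, is all that is known. Compound 3 `Cc1ccccc1NS(=O)(=O)c1ccc(NC(=O)c2ccc(Cl)cc2Cl)cc1` carries 2-methylphenyl in place of pyrimidin-2-yl on a sulfonamide nitrogen. For the measured compounds named here, no measured step bears readably on this change, so neither direction nor size can be taken from the data. Compound 3 is expected to sit at the limit too, estimated at 100000 nM within 20000 nM to 300000 nM. The step this expectation implies is a number no higher from compound 2 to compound 3 (the limit leaves the size open).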

Compound 3, half-maximal effective concentration: 1230 nM
Compound 3: the middle estimate sits 81-fold (1.91 log units) above what was measured; measured number below the stated range.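

In this assay the substituent on the sulfonamide nitrogen is now shown to matter: 2-methylphenyl in place of pyrimidin-2-yl gives an at least 81-fold lower number from compound 2 to compound 3 (1.91 log units; beyond the scatter) and 2-methylphenyl in place of benzoyl gives an at least 81-fold lower number from compound 1 to compound 3 (1.91 log units; beyond the scatter) as well. Going by these compounds, compound 3 is the only one of the three with a value that is a number and not a limit, and both steps stay open-ended on their weaker side.

On these data alone, whether the methyl group of 2-methylphenyl is needed remains open, as does the outcome with a plain phenyl or a cyclohexyl group on this nitrogen.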